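The source may hold more compounds than are shown below. What is called first, only, known or untested is meant among the compounds shown, and "the series" means these compounds.

In a physicochemical assay for solubility, read by chemiluminescence, measured as kinetic solubility (on this read-out higher numbers stand for higher solubility and lower numbers for lower solubility), compound 3 `O=C(c1ccccn1)N1CCC2(CCN(c3nccc(NCc4ccc(Cl)cc4Cl)n3)CC2)C1` gives 17 ug/mL, the middle of three numbers, while compound 1 `O=C(C1CCCN1)N1CCC2(CCN(c3nccc(NCc4ccc(Cl)cc4Cl)n3)CC2)C1` gives 79 ug/mL and compound 2 `O=C(C1CCCCC1)N1CCC2(CCN(c3nccc(NCc4ccc(Cl)cc4Cl)n3)CC2)C1` gives 3 ug/mL. Compound 4 `Clc1ccc(CNc2ccnc(N3CCC4(CCN(C[C@H]5CCCN5)C4)CC3)n2)c(Cl)c1` differs from compound 3 in one place: (pyrrolidin-2-yl)methyl in place of (pyridin-2-yl)carbonyl on an amine nitrogen in a ring. The nearest evidence comes from swaps on the carbonyl carbon. Pyridin-2-yl in place of pyrrolidin-2-yl gave a modest step, a 4.6-fold lower number from compound 1 to compound 3 (0.67 log units; beyond the scatter), and cyclohexyl in place of pyrrolidin-2-yl gave a large one, a 26-fold lower number from compound 1 to compound 2 (1.42 log units; beyond the scatter). Within the data shown here, compound 4 also carries a pyrrolidin-2-yl group, but no measured compound lacks the carbonyl, so this guide is indirect. In this assay a modest rise is expected, a 4.1-fold higher number from compound 3 to compound 4 (0.61 log units; beyond the scatter). For compound 4 the estimate is 70 ug/mL, with a range of 20 ug/mL to 200 ug/mL.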

Compound 4, solubility: 16 ug/mL
For compound 4 the middle estimate is 4.4-fold (0.64 log units) above the measured one, and the stated range ends above it.
By their numbers in this assay, from the lowest: compound 2; then compounds 4 and 3 (each within the scatter of the next); then compound 1.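

In this assay the pyrrolidin-2-yl group stays while a methyl link replaces the carbonyl link, giving a 4.9-fold lower number from compound 1 to compound 4 (0.69 log units; beyond the scatter) and showing that the ring alone does not set the number at this amine nitrogen. Against the other two groups, the same change gives a 1.1-fold lower number from compound 3 to compound 4 (0.03 log units; within the scatter) and a 5.3-fold higher number from compound 2 to compound 4 (0.73 log units; beyond the scatter) so the link and the ring both count here. Nothing measured here explains these steps. Still open, from the compounds shown here alone, is how a cyclohexylmethyl or (pyridin-2-yl)methyl group would compare with its carbonyl partner. A longer chain before the pyrrolidine ring, or a carboxylic acid on it, also remains to be seen.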